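Chloro to Methoxy on a Shared Core

The source may hold more compounds than are shown below. What is called first, only, known or untested is meant among the compounds shown, and "the series" means these compounds.

Of the compounds shown here, three built on a shared core have been tested in a functional assay on the whole organism with Mus musculus as the target, in the maximal electroshock model, with a stated time of 4 h; on this read-out lower numbers stand for an effect already at smaller amounts and higher numbers for an effect only at larger amounts of compound. Compound 1 `CC(=O)c1ccc2nc(NC(=O)CCC(=O)c3ccccc3)sc2c1` gives 100 mg/kg, compound 2 `O=C(CCC(=O)c1ccccc1)Nc1nc2cc(Cl)c(F)cc2s1` gives 300 mg/kg, and compound 3 `O=C(Nc1nc2ccc(Cl)cc2s1)c1ccccc1C(=O)c1ccccc1` gives 100 mg/kg. Compound 3 stands level with compound 1 at the digits shown, while compound 2 gives a higher number, a gap beyond the usual scatter. Compound 4 `COc1ccc2nc(NC(=O)c3ccccc3C(=O)c3ccccc3)sc2c1` differs from compound 3 in one place: methoxy in place of chloro on an aromatic carbon. Among the measured compounds shown here, no pair of measured compounds shows this exact change, so there is no measured step to lean on. The expected step is no change at the digits printed from compound 3 to compound 4 (within the scatter), not beyond the scatter in either direction. The estimate for compound 4 is 100 mg/kg, within 50 mg/kg to 300 mg/kg.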

Compound 4, minimum effective dose: 100 mg/kg
For compound 4 middle estimate and measured number coincide at the digits printed; measured number inside the range.
By their numbers in this assay, from the lowest: compounds 1, 3 and 4 (each within the scatter of the next); then compound 2.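

In this assay, among the compounds shown here, methoxy in place of chloro on an aromatic carbon gives no change at the digits printed from compound 3 to compound 4 (within the scatter), the first step in this set that differs in one place only. At this position, two heavy atoms including a hydrogen-bond acceptor can therefore stand where one chlorine stood, with the number holding level. No supporting measurement offers a reason for this result. On these data alone, whether an amine or a carboxylic acid at this position would hold the same level remains open. So does whether a longer chain, such as ethoxy, would do so.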